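A few compounds are considered here, and "the series" means these few. Any claim that something is new, unique, unknown or untested is made for them only; others in the source may bear on it.

Measured so far in a functional assay on A549 cells (Homo sapiens) for inhibition, read by MTT assay, with a stated time of 48 h; a higher number here means a weaker inhibitor, a lower number a stronger inhibitor:

compound 1 `Cc1ccccc1NC(=O)/C=C/c1coc2cc(O)ccc2c1=O` gives > 100000 nM, a limit of this assay rather than a number.
compound 2 `COc1ccc(CNC(=O)/C=C/c2coc3cc(OC)ccc3c2=O)cc1` gives 22500 nM.
compound 3 `COc1ccc2c(=O)c(/C=C/C(=O)NCc3ccccc3F)coc2c1` gives > 100000 nM, again a limit and not a number.

Compound 3 therefore stands at the upper edge of what this assay reports; of the three values shown, two sit at that edge (the limit of > 100000 nM in this assay, at which 2 of the 3 values shown sit), and only compound 2 gives a measurable number.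

Among the compounds with values here, the one measured step that touches the group on the saturated chain carbon bound to the amide-type nitrogen is an at least 4.4-fold higher number from compound 2 to compound 3 (0.64 log units; beyond the scatter), and since it ends at a limit its true size is known only as a lower bound.

Compound 4 `COc1ccc2c(=O)c(/C=C/C(=O)NCc3ccc(F)cc3F)coc2c1` differs from compound 3 by fluoro in place of hydrogen on an aromatic carbon. Within the data shown here, no measured step of this kind exists: the step from compound 2 to compound 3 exchanges the whole aryl group, not a single fluoro on a ring that already carries one, and so gives no direction for the present change.

Starting from a limit, compound 4 is expected to stay at or near that limit in this assay, an estimate of 150000 nM with a range of 40000 nM to 600000 nM, which means an expected step that the limit leaves unreadable from compound 3 to compound 4.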

Compound 4, half-maximal inhibitory concentration: 13300 nM
The estimate for compound 4 lay 11-fold (1.05 log units) above the measured number; measured number below the stated range.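

In this assay, fluoro in place of hydrogen on the aromatic carbon para to a large group, which turns 2-fluorobenzyl into 2,4-difluorobenzyl, gives an at least 7.5-fold lower number from compound 3 to compound 4 (0.87 log units; beyond the scatter) and so shows that this single atom is enough to bring the series back from the edge of the read-out. The aryl group itself therefore does not decide the outcome, since a 1.7-fold lower number from compound 2 to compound 4 (0.23 log units; within the scatter) leaves 2,4-difluorophenyl and 4-methoxyphenyl unseparated, and among compounds 2, 3 and 4 the two aryl groups with a substituent at that place give numbers, while the one with hydrogen there does not. The true size of the gain remains a lower bound because compound 3 stands at a limit: the limit of > 100000 nM in this assay, at which 2 of the 4 values shown sit.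

From the compounds shown here alone, whether the fluoro at that place matters as fluoro or whether any substituent there would serve stays open, and chloro, a hydroxyl or an amine at the same carbon would separate these readings. Also open, going by these compounds, is what the remaining 2-fluoro contributes, which 4-fluorobenzyl would show, and whether a longer chain between the amide nitrogen and the ring keeps the effect.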